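The source may report more compounds than this note shows. Statements on the series, on what has been measured and on what is new or still open speak of the compounds shown alone.

Working notes on a small series sharing the core of compound 1 `O=C(/C=C\Nc1ccc(C(F)(F)F)cc1)c1cn(-c2ccccc2)nc1-c1ccc(Cl)cc1`. In a functional assay on HT-29 cells (Homo sapiens) for antiproliferative activity, read by MTT assay, with a stated time of 48 h (a lower number here means a stronger inhibitor, a higher number a weaker inhibitor), compound 1 gives only a limit, > 50000 nM. Compound 2 `O=C(/C=C\Nc1ccc(O)cc1)c1cn(-c2ccccc2)nc1-c1ccc(Cl)cc1` gives 2500 nM in this assay, and compound 3 `COc1ccc(N/C=C\C(=O)c2cn(-c3ccccc3)nc2-c2ccc(Cl)cc2)cc1` gives 8930 nM. The step of an at least 20-fold lower number from compound 1 to compound 2 (1.30 log units; beyond the scatter) and the step of an at least 5.5-fold lower number from compound 1 to compound 3 (0.74 log units; beyond the scatter) both start from the limit of > 50000 nM in this assay, at which 1 of the 3 values shown sits, and are therefore minimum sizes only. Between the two compounds with numbers, the step of a 3.6-fold higher number from compound 2 to compound 3 (0.55 log units; beyond the scatter) separates them. Going by the values given here, compound 3 thus stands at the higher of the two numbers this assay has returned, with compound 2 its only neighbour, below it by the step just named.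

Compound 4 `COc1ccc(N/C=C\C(=O)c2cn(-c3ccccc3)nc2-c2ccc(OC)cc2)cc1` differs from compound 3 by methoxy in place of chloro on an aromatic carbon. Among the compounds with values here, none of the measured steps touches this position: all three alter the substituent on the other aromatic ring, while the 4-chlorophenyl is held constant in compounds 1, 2 and 3. Within the data shown here, no measured step bears directly on the change, and with no guide in either direction the expected step of a 1.0-fold higher number from compound 3 to compound 4 (0.00 log units; within the scatter) is set as none beyond the scatter. Compound 4 is accordingly estimated at 9000 nM in this assay, with a range from 3000 nM to 30000 nM.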

Compound 4, half-maximal inhibitory concentration: 8760 nM
Compound 4: the middle estimate sits 1.0-fold (0.01 log units) above what was measured, within the range that was stated.
By their numbers in this assay, from the lowest: compound 2; then compounds 4 and 3 (each within the scatter of the next). At a limit, above all of these: compound 1.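

In this assay, going by these compounds alone, the step of a 1.0-fold lower number from compound 3 to compound 4 (0.01 log units; within the scatter) is the first reading at this position, and it lies within the scatter. With the methoxy group on the other aromatic ring held constant, this assay therefore does not separate 4-chlorophenyl from 4-methoxyphenyl, whereas all three earlier steps, each made on that other ring, lie beyond the scatter. Nothing in the data at hand accounts for this result.

Going by these compounds, the finding rests on a single matched pair, so it remains open whether the same exchange would also stay within the scatter with the hydroxy group of compound 2 on the other ring, or with the trifluoromethyl group of compound 1, whose value is only a limit. On these data alone, it also remains open whether a different group on this ring, such as an amine, a carboxylic acid or a longer alkoxy chain, or plain hydrogen in place of chloro, would shift the number beyond the scatter in either direction.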